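Compound 2 and a lengthened amide arm

A few compounds are considered here, and "the series" means these few. Any claim that something is new, unique, unknown or untested is made for them only; others in the source may bear on it.

Compound 2 `Cn1cc(-c2ccc(=O)n(CCOc3ccnc4cc(OCc5ccc(C(=O)Nc6ccccc6N)cc5)ccc34)n2)cn1` gives 1800 nM in a functional assay on HCT-116 cells (Homo sapiens) for antiproliferative activity, read by sulforhodamine B assay, with a stated time of 72 h (on this read-out higher numbers stand for weaker inhibition and lower numbers for stronger inhibition), and holds the lowest of the two actual numbers in the series. Compound 3 `Cn1cc(-c2ccc(=O)n(CCOc3ccnc4cc(OCc5ccc(/C=C/C(=O)Nc6ccccc6N)nc5)ccc34)n2)cn1` gives 7900 nM as a higher number, beyond the scatter of repeated measurements. Compound 1 `Cn1cc(-c2ccc(=O)n(CCOc3ccnc4cc(OCCCCC(=O)NO)ccc34)n2)cn1` reads > 10000 nM and this is a limit of the assay, not a number.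

Compound 4 `Cn1cc(-c2ccc(=O)n(CCOc3ccnc4cc(OCc5ccc(CCC(=O)Nc6ccccc6N)cc5)ccc34)n2)cn1` is still unmeasured. It carries 2-((2-aminophenyl)carbamoyl)ethyl in place of the (2-aminophenyl)carbamoyl of compound 2 on an aromatic carbon 2-((2-aminophenyl)carbamoyl)ethyl in place of (2-aminophenyl)carbamoyl on an aromatic carbon and keeps the shared core. Among the compounds with values here, no measured pair isolates this change. The nearest guide is compound 3 at 7900 nM. Compound 3 also has a spacer ahead of its amide, though it differs from compound 2 in other ways too. In this assay the expected step of a 1.9-fold higher number from compound 2 to compound 4 (0.29 log units; within the scatter) is moderate and toward a higher number, meaning weaker inhibition, although a result within the scatter remains possible. Compound 4 is estimated at 3500 nM with an expected range of 1200 nM to 10000 nM for the measurement to come.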

Compound 4, half-maximal inhibitory concentration: > 10000 nM
Compound 4 ended at the assay's limit; the forecaster's own chance of this, stated with the estimate: 10%; middle value at least 2.8-fold (0.45 log units) from the limit.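

In this assay, 2-((2-aminophenyl)carbamoyl)ethyl in place of (2-aminophenyl)carbamoyl on an aromatic carbon, para to a large group, gives an at least 5.5-fold higher number from compound 2 to compound 4 (0.74 log units; beyond the scatter). Within the data shown here, this is the first step that isolates a single place, and it shows that the lengthened amide arm costs antiproliferative activity on this scaffold, which the earlier compounds, differing in several places, could not show. Compound 4 stands at a limit of the assay and not at a number, so only the lower bound of the step is known: the limit of > 10000 nM in this assay, at which 2 of the 4 values shown sit.

The compounds shown leave open how a single methylene spacer ahead of the amide would read at this position. Compound 3 differs from compound 2 in more than one place, so the effect of its unsaturated spacer cannot be separated from that of its ring.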